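Chloro for methoxy on a triazole-thiol aryl group

This account rests on a few compounds, and the source may have more. Where it says the series, first, only, none or still open, it means among the compounds named here.

Measured compounds:
- compound 1, `COc1ccc(-n2c(S)nnc2Sc2nnc(-c3ccccc3)n2-c2ccccc2)cc1`: "not determined" (no result reported)
- compound 2, `Sc1nnc(CSc2nnc(-c3ccccc3)n2-c2ccccc2)n1-c1ccccc1`: 8570 nM
- compound 3, `CC(C)n1c(S)nnc1CSc1nnc(-c2ccccc2)n1-c1ccccc1`: "not determined" (no result reported)

Three compounds sharing one core have been examined in a functional assay on MDA-MB-231 cells (Homo sapiens) for inhibition, read by MTT assay, with a stated time of 48 h; on this read-out lower numbers stand for stronger inhibition and higher numbers for weaker inhibition. Compound 1 stands without a number: in this assay compound 1 gives "not determined" (no result reported), and compound 3 likewise gives "not determined" (no result reported). Among the compounds with values here, the only number comes from compound 2, which in this assay gives 8570 nM. So compound 1 cannot be placed against either neighbour on the numbers shown; it is simply unmeasured.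

The unmeasured compound 4, `Sc1nnc(Sc2nnc(-c3ccccc3)n2-c2ccccc2)n1-c1ccc(Cl)cc1`, differs from compound 1 in one place: chloro in place of methoxy on an aromatic carbon. Within the data shown here, no step between measured compounds is available to say what such a change does here. Among the measured compounds shown here, since compound 1 has no number to start from, the direction of the step in this assay is unknown, and the change could as well fall within the scatter as beyond it in either direction; the single measured value of compound 2 is the only anchor for the series. On that basis compound 4 is expected to give about 8000 nM, with a range from 2000 nM to 35000 nM.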

Compound 4, half-maximal inhibitory concentration: 49700 nM
For compound 4 the middle estimate is 6.2-fold (0.79 log units) below the measured one, outside the stated range (above it).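

Within the data shown here, compound 1 carries no single number in this assay, so no step from it to compound 4 can be read. The compounds shown leave open what the change from 4-methoxyphenyl to 4-chlorophenyl does in this assay on this core. No evidence shown here bears on the result for compound 4.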